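This account rests on a few compounds, and the source may have more. Where it says the series, first, only, none or still open, it means among the compounds named here.

Series notes. Compound 1 `Cc1cccc(NC(=O)CN2CCC(c3ccccc3C#N)CC2)c1` is the higher of the two measured compounds in a functional assay on HEK293 cells for agonist activity at D(4) dopamine receptor (Homo sapiens), read by FLIPR (on this read-out higher numbers stand for larger maximal responses and lower numbers for smaller maximal responses), where compound 1 gives 71%. Compound 2 `O=C(NCN1CCC(c2cccc[n+]2[O-])CC1)c1ccc(OC(F)(F)F)c(Cl)c1` gives 33% in this assay, a gap beyond the usual scatter; no single-point change links the two, so their numbers only mark the spread seen so far. Compound 3 `Cc1cccc(NC(=O)CN2CCC(c3ccccc3C)CC2)c1` is the next member, not yet measured. It differs from compound 1 in one place: methyl in place of cyano on an aromatic carbon The change sits on an aromatic carbon of a six-membered aromatic ring of carbon only, ortho to a large group. Nothing measured shows how this assay answers such a swap, so the expectation rests on compound 1 alone. The expected step from compound 1 to compound 3 is a number 16 percentage points lower from compound 1 to compound 3 (beyond the scatter), a moderate fall, though an outcome within the scatter cannot be ruled out. For compound 3 the estimate is 55%, with a range from 30% to 80%.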

Compound 3, largest response reached (reported as efficacy), in percent of the reference or control that the assay uses: 43%
For compound 3 the middle estimate is 12 percentage points above the measured one, and the stated range covers the measured number.
By their numbers in this assay, from the lowest: compounds 2 and 3 (each within the scatter of the next); then compound 1.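

For the compounds shown here, this is the first single-point step: at this aromatic carbon, ortho to a large group, methyl in place of cyano gives a number 28 percentage points lower from compound 1 to compound 3 (beyond the scatter) in this assay. The read-out therefore responds to the group at this place, and the 2-cyanophenyl form carries the larger maximal response of this pair, though the 2-methylphenyl form in compound 3 still gives 43%. Nothing available bears on why the two groups differ here.

With only cyano and methyl seen at this place, the compounds shown leave open how a fluorine, a methoxy group or a primary amide would read there. Also open, as far as these compounds go, is whether the same swap gives a like step on a core other than that of compound 1.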